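Swapping a difluorophenyl for a sulfamoylphenyl

The compounds below may be only part of what the source reports. "The series", "measured", "known", "first", "only" and "open" are said of these compounds alone.

Compound 1, `COc1ccc(OC)c(-c2nc(C(c3ccccc3)c3ccccc3)sc2CC(=O)O)c1`: in an in vitro assay on HEK385-7 cells for displacement of a labelled ligand from prostaglandin D2 receptor 2 (Homo sapiens) (on this read-out lower numbers stand for stronger inhibition and higher numbers for weaker inhibition), compound 1 gives > 105 nM, which is a limit of the assay and not a number.
Compound 2, `O=C(O)Cc1sc(C(c2ccc(F)cc2)c2ccc(F)cc2)nc1-c1cc(F)cc(F)c1`: in this assay compound 2 gives 35 nM.

Compound 2 thus holds the only real number shown; the other value is only a limit (the limit of > 105 nM in this assay, at which 1 of the 2 values shown sits). Compound 3, `NS(=O)(=O)c1cccc(-c2nc(C(c3ccc(F)cc3)c3ccc(F)cc3)sc2CC(=O)O)c1`, differs from compound 2 by 3-sulfamoylphenyl in place of 3,5-difluorophenyl on an aromatic carbon. Among the compounds with values here, no pair of measured compounds shows what such a change does, so the expectation rests on compound 2 alone. The change is expected to cost a little binding, so the step from compound 2 to compound 3 is estimated as a 1.7-fold higher number from compound 2 to compound 3 (0.23 log units; within the scatter). Compound 3 is therefore estimated at 60 nM, likely between 15 nM and 250 nM.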

Compound 3, half-maximal inhibitory concentration: 140 nM
The estimate for compound 3 lay 2.3-fold (0.37 log units) below the measured number; measured number inside the range.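

This position responds to what it carries. In this assay the change gives a 4.0-fold higher number from compound 2 to compound 3 (0.60 log units; beyond the scatter) and so shows that 3-sulfamoylphenyl binds less well here than 3,5-difluorophenyl. Compound 3 still gives 140 nM as a real number, so binding is weakened, not lost. Nothing measured here explains the rise.

Going by these compounds, the two groups differ in more than one feature, so it stays open whether the sulfamoyl group or the missing fluorines account for the step. A plain phenyl or a methylsulfonylphenyl at this position could help separate the two.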